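Amide Variation at the Aryl End of an Adenosine Deaminase Inhibitor

The source may report more compounds than this note shows. Statements on the series, on what has been measured and on what is new or still open speak of the compounds shown alone.

Measured so far:
Compound 1, `C[C@H](O)[C@@H](CCc1cccc(CO)c1)n1cnc2c(N)ncnc21`, gives 4.6 nM in an assay on isolated protein for inhibition of adenosine deaminase (Bos taurus), with a stated time of 5 min; on this read-out lower numbers stand for stronger inhibition and higher numbers for weaker inhibition.
Compound 2, `C[C@H](O)[C@@H](CCc1cccc(C(=O)NC2CCCC2)c1)n1cnc2c(N)ncnc21`, gives 1.8 nM in this assay.

Within the data shown here, compound 2 holds the lower of the two numbers; the single measured step, a 2.6-fold lower number from compound 1 to compound 2 (0.41 log units; beyond the scatter), lies beyond the scatter. Compound 3, `C[C@H](O)[C@@H](CCc1cccc(C(=O)N2CCCC2)c1)n1cnc2c(N)ncnc21`, differs from compound 2 by pyrrolidin-1-yl in place of cyclopentylamino on a carbonyl carbon. Among the measured compounds shown here, no measured step covers this change directly; the one step in hand, a 2.6-fold lower number from compound 1 to compound 2 (0.41 log units; beyond the scatter), concerns the other end of the same substituent and gives only indirect guidance. The expected step is therefore small, a 1.7-fold higher number from compound 2 to compound 3 (0.22 log units; within the scatter), not clearly beyond the scatter in either direction. Compound 3 is estimated at 3 nM, with a range from 1 nM to 9 nM.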

Compound 3, inhibition constant: 2.2 nM
Estimate against measurement, compound 3: 1.4-fold (0.13 log units) above, within the range that was stated.
By their numbers in this assay, from the lowest: compounds 2 and 3 (each within the scatter of the next); then compound 1.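

Read in this assay, replacing cyclopentylamino with pyrrolidin-1-yl removes the amide hydrogen and gives a 1.2-fold higher number from compound 2 to compound 3 (0.09 log units; within the scatter), so on this carbonyl carbon the two amides cannot be told apart. The advantage over hydroxymethyl seen with the first amide also appears with the second, as a 2.1-fold lower number from compound 1 to compound 3 (0.32 log units; beyond the scatter) shows. No available evidence bears on this result.

Still open, as far as these compounds go, is whether an open-chain amide such as the diethylamide, or a carboxylic acid on the same aromatic carbon, would keep the number in this range.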